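Same sulfonamide swap tried on a second core

The source may report more compounds than this note shows. Statements on the series, on what has been measured and on what is new or still open speak of the compounds shown alone.

Measured compounds:
- compound 1 `CC(C)(C)c1cc(C(C)(C)C)c2oc(=O)c(/C=N/c3ccc(S(=O)(=O)Nc4nccs4)cc3)c(Cl)c2c1`: 160 nM
- compound 2 `CC(C)(C)c1cc(C(C)(C)C)c2oc(=O)c(/C=N/c3ccc(S(=O)(=O)NC(=N)N)cc3)c(Cl)c2c1`: 250 nM
- compound 3 `Cc1ccc2oc(=O)c(/C=N/c3ccc(S(=O)(=O)Nc4nccs4)cc3)c(Cl)c2c1`: 280 nM

All three were tested in a functional assay on B16-F10 cells (Mus musculus) for cytotoxicity, read by CCK-8 assay, with a stated time of 48 h; on this read-out higher numbers stand for weaker inhibition and lower numbers for stronger inhibition. Compounds 1 and 2 share one core and differ only on a sulfonamide nitrogen: a group of 3 heavy atoms (1 carbon, 2 nitrogen; no ring) in place of a group of 5 heavy atoms (3 carbon, 1 nitrogen, 1 sulfur; one five-membered aromatic ring with 2 hetero atoms), on a sulfonamide nitrogen. The step this made, a 1.6-fold higher number from compound 1 to compound 2 (0.19 log units; within the scatter), is small enough to count as no real change. Compound 3 carries a different core with the same sulfonamide substituent as compound 1; how the two cores differ is not broken down here. The numbers for compound 3 and compound 1 lie within the scatter of each other, as do those for compound 3 and compound 2.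

Compound 4 `Cc1ccc2oc(=O)c(/C=N/c3ccc(S(=O)(=O)NC(=N)N)cc3)c(Cl)c2c1` is not yet measured. It stands to compound 3 as compound 2 stands to compound 1: a group of 3 heavy atoms (1 carbon, 2 nitrogen; no ring) in place of a group of 5 heavy atoms (3 carbon, 1 nitrogen, 1 sulfur; one five-membered aromatic ring with 2 hetero atoms), on a sulfonamide nitrogen. The place is the same in both pairs, so this is the same change made on a second core. For the measured compounds named here, the only guide is the step from compound 1 to compound 2, which was within the scatter, and there is nothing to show that the second core would respond otherwise. Compound 4 is therefore expected to sit close to compound 3, with an estimated step of a 1.6-fold higher number from compound 3 to compound 4 (0.21 log units; within the scatter) in this assay, resting on a 1.6-fold higher number from compound 1 to compound 2 (0.19 log units; within the scatter). The estimate for compound 4 in this assay is 450 nM, likely between 230 nM and 900 nM.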

Compound 4, half-maximal inhibitory concentration: 240 nM
For compound 4 the middle estimate is 1.9-fold (0.27 log units) above the measured one; measured number inside the range.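

On the second core, replacing the 1,3-thiazol-2-yl group on the sulfonamide nitrogen with the small ring-free group gives, in this assay, a 1.2-fold lower number from compound 3 to compound 4 (0.07 log units; within the scatter), so the swap again makes no real difference to the number. Set side by side, the steps on the two cores agree: the same change on two cores in this assay, a 1.6-fold higher number (0.19 log units; within the scatter) from compound 1 to compound 2 and a 1.2-fold lower number (0.07 log units; within the scatter) from compound 3 to compound 4, 1.8-fold (0.26 log units) apart, within the scatter of two such steps This shows that on these two cores the thiazole ring can be exchanged for the ring-free group with no real change in this cell read-out, but the opposite directions of the two steps carry no meaning, and two cores cannot show that the same would hold on every core in the series, nor why the numbers stay so close.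

The compounds shown leave open what other groups on the sulfonamide nitrogen would do, such as a single methyl group, an acetyl group or a pyridine ring, and whether any of them would move the number beyond the usual scatter. They also leave open whether the swap would stay this quiet on a core that carries a carboxylic acid or an amine.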